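This account rests on a few compounds, and the source may have more. Where it says the series, first, only, none or still open, it means among the compounds named here.

Measured compounds:
compound 1 `COc1ccc(CCCc2ccc(OC)c(OC)c2)c(O)c1`: 88.9%
compound 2 `COc1ccc(CCCc2ccc(OC)cc2O)cc1`: 94.6%
compound 3 `COc1ccc(C(=O)CCc2ccc(OC)c(OC)c2)c(O)c1`: 75.2%

In an ADME assay on RAW264.7 cells (Mus musculus) for cytotoxicity, read by MTT assay, with a stated time of 24 h, tested at 5 ug/mL (a higher number here means a weaker effect of the compound at the concentration tested, a lower number a stronger effect), compound 3 gives the lowest of the three numbers; compound 1 and compound 2 both stand beyond the scatter above it. Between compound 2 and compound 1 the change is methoxy in place of hydrogen on an aromatic carbon, and the step is a number 5.7 percentage points lower from compound 2 to compound 1 (within the scatter).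

Compound 4 `COc1ccc(C(=O)CCc2ccc(OC)c(OC)c2OC)c(O)c1` is unmeasured. It arises from compound 3 by methoxy in place of hydrogen on an aromatic carbon, the same kind of change as from compound 2 to compound 1, but the surroundings differ: in compound 4 the new methoxy sits ortho to a large group, ortho to a methoxy group and meta to a methoxy group, whereas in compound 1 it sits ortho to a methoxy group and meta to a large group. The difference between the cores of compound 3 and compound 2 is not broken down here.

Because a number 5.7 percentage points lower from compound 2 to compound 1 (within the scatter) lay within the scatter, a step of about a number 5.2 percentage points lower from compound 3 to compound 4 (within the scatter) is expected in this assay. For compound 4 the estimate is 70%, between 56% and 84%.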

Compound 4, a percentage reported as activity, at one concentration (the size of the read-out at that concentration, not a potency): 94.8%
Compound 4: the middle estimate sits 24.8 percentage points below what was measured, and the stated range ends below it.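

In this assay, methoxy in place of hydrogen on an aromatic carbon gives a step of a number 19.6 percentage points higher from compound 3 to compound 4 (beyond the scatter), and this change does not carry over as one fixed step between the two cores: the same change on two cores in this assay, a number 5.7 percentage points lower (within the scatter) from compound 2 to compound 1 and a number 19.6 percentage points higher (beyond the scatter) from compound 3 to compound 4, 25.3 percentage points apart, beyond the scatter of two such steps

The two pairs differ in the core and also in where the methoxy sits, since in compound 4 it is ortho to a large group, ortho to a methoxy group and meta to a methoxy group, so core and placement cannot be told apart. With one pair on each core, this shows no rule for either core.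

The compounds shown leave open what this same placement would do on the core of compound 1. They also leave open how an amine or a carboxylic acid at that carbon would compare with methoxy.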